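From Chloro to Acetamido: One Step in Cytotoxicity

This account rests on a few compounds, and the source may have more. Where it says the series, first, only, none or still open, it means among the compounds named here.

Compound 1 `O=C1/C(=C/c2cccnc2)CN(S(=O)(=O)c2ccccc2)C/C1=C\c1ccccc1F` and compound 2 `O=C1/C(=C/c2cccnc2)CN(S(=O)(=O)c2ccc(Cl)cc2)C/C1=C\c1ccccc1F` have both been tested in a functional assay on SMMC-7721 cells (Homo sapiens) for cytotoxicity, read by MTT assay, with a stated time of 24 h (on this read-out lower numbers stand for stronger inhibition and higher numbers for weaker inhibition), and their numbers lie close together. Within the data shown here, compound 1 gives 19100 nM there and compound 2 gives 16100 nM in the same test, which leaves compound 2 within the scatter of its only measured neighbour. Compound 3 `CC(=O)Nc1ccc(S(=O)(=O)N2C/C(=C\c3cccnc3)C(=O)/C(=C/c3ccccc3F)C2)cc1` has not yet been measured. It carries acetamido in place of chloro on an aromatic carbon, para to a large group, and the difference from compound 2 counts as acetamido in place of chloro on an aromatic carbon in full. Among the measured compounds shown here, the only measured step that bears on this change is a 1.2-fold lower number from compound 1 to compound 2 (0.07 log units; within the scatter) for chloro in place of hydrogen on an aromatic carbon. For the measured compounds named here, no compound with acetamido has been measured, so that small step offers limited guidance, and no shift beyond the scatter is expected. The expected change is a 1.1-fold higher number from compound 2 to compound 3 (0.02 log units; within the scatter) on this reasoning. In this assay compound 3 is estimated at 17000 nM with an expected range of 7000 nM to 40000 nM around that figure.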

Compound 3, half-maximal inhibitory concentration: 10900 nM
Compound 3: the middle estimate sits 1.6-fold (0.19 log units) above what was measured; the measured number falls inside the stated range.
By their numbers in this assay, from the lowest: compounds 3, 2 and 1 (each within the scatter of the next).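

The earlier pair compared only chloro with hydrogen on this aromatic carbon, para to a large group, whereas compound 3 places acetamido there, bringing a hydrogen-bond donor and a hydrogen-bond acceptor that chloro lacks. In this assay, replacing chloro with acetamido gives a 1.5-fold lower number from compound 2 to compound 3 (0.17 log units; within the scatter), and the comparison with hydrogen at the same place gives a 1.8-fold lower number from compound 1 to compound 3 (0.24 log units; within the scatter), so neither step lies beyond the scatter and this read-out does not separate hydrogen, chloro and acetamido at this position. No supporting data are available to explain this result.

The compounds shown leave open whether a free amine, a carboxylic acid or a longer acyl chain such as butyramido at this same position would produce a step beyond the scatter in this assay. They also leave open whether acetamido would behave in the same way at another place on the six-membered aromatic ring, or whether changes to the 2-fluorophenyl or pyridyl parts of the shared core would matter more than changes at this position.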